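The source may report more compounds than this note shows. Statements on the series, on what has been measured and on what is new or still open speak of the compounds shown alone.

Of the compounds shown here, three of a shared core have been tested in a functional assay on HeLa cells (Homo sapiens) for cytotoxicity, read by MTT assay, with a stated time of 72 h, tested at 1 uM; on this read-out lower numbers stand for less inhibition of growth and higher numbers for more inhibition of growth at the one concentration tested. Compound 1 `N/C(=N\NC(=S)N1CCOCC1)c1ccccn1` gives 12.7%. Compound 2 `N/C(=N\NC(=S)N1CCCC1)c1ccc(F)cn1` gives 62.8%, and compound 3 `N/C(=N\NC(=S)N1CCSCC1)c1ccc(F)cn1` gives 19.6%. Among these three numbers compound 3 stands second highest; its number and that of compound 1 lie within the scatter of each other, whereas the gap to compound 2 is beyond it. For the measured compounds named here, the one step between compounds that differ in a single place, a number 43.2 percentage points lower from compound 2 to compound 3 (beyond the scatter), is large and runs downward.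

Compound 4 `N/C(=N\NC(=S)N1CCOCC1)c1ccc(F)cn1` has not yet been measured in this assay. Compared with compound 3 the difference is morpholin-4-yl in place of thiomorpholin-4-yl on a thiocarbonyl carbon. Going by the values given here, no measured pair shows exactly this exchange, so the step from compound 2 to compound 3 bears on it only indirectly: it shows that the group on the thiocarbonyl carbon can move the number by a large amount, but it compares pyrrolidin-1-yl with thiomorpholin-4-yl, not thiomorpholin-4-yl with morpholin-4-yl. Compound 1, which also carries morpholin-4-yl, shows a number within the scatter of compound 3. On that basis the step from compound 3 to compound 4 is expected to stay within the scatter, a number 3.6 percentage points lower from compound 3 to compound 4 (within the scatter). Compound 4 is therefore estimated at 16%, within a range from 4% to 35%.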

Compound 4, percent growth inhibition at one concentration: 21.4%
Estimate against measurement, compound 4: 5.4 percentage points below, within the range that was stated.
By their numbers in this assay, from the lowest: compounds 1, 3 and 4 (each within the scatter of the next); then compound 2.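

In this assay, the exchange of thiomorpholin-4-yl for morpholin-4-yl on a thiocarbonyl carbon comes to a number 1.8 percentage points higher from compound 3 to compound 4 (within the scatter) and so gives no difference that can be told apart, which means that with the shared core, the fluoro group and the ring size held fixed, sulfur and oxygen in this six-membered ring read alike. The large loss seen earlier with thiomorpholin-4-yl now has a counterpart with morpholin-4-yl, at a number 41.4 percentage points lower from compound 2 to compound 4 (beyond the scatter) for the exchange from pyrrolidin-1-yl, so at this position both six-membered rings stand apart from the pyrrolidin-1-yl of compound 2. For the compounds shown here, the first comparison of the aromatic position, fluoro in place of hydrogen on an aromatic carbon with morpholin-4-yl kept, gives a number 8.7 percentage points higher from compound 1 to compound 4 (within the scatter) and thus shows no difference beyond the scatter for this pair.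

Going by these compounds, it remains open where piperidin-1-yl, a six-membered ring with no second hetero atom, or an open-chain diethylamino group would fall on this thiocarbonyl carbon, and whether the fluoro exchange would read the same alongside pyrrolidin-1-yl. Nothing at hand offers an explanation for any of these steps.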